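Cytotoxicity tolerance after a propylsulfanyl exchange

A few compounds are considered here, and "the series" means these few. Any claim that something is new, unique, unknown or untested is made for them only; others in the source may bear on it.

Compound 2 `COc1cnc(-n2cnc(N3CCN(C)CC3)n2)c2[nH]cc(C(=O)C(=O)N3CCN(C(=O)c4ccccc4)CC3)c12` stands at a limit in a functional assay on MT2 cells (Homo sapiens) for cytotoxicity, read by XTT assay, with a stated time of 3 days; a higher number here means that more compound is tolerated, a lower number that less compound is tolerated: its value of > 300000 nM is a limit of the assay, not a number. Compound 1 `COc1cnc(-n2ccc(CN(C)C)n2)c2[nH]cc(C(=O)C(=O)N3CCN(C(=O)c4ccccc4)[C@H](C)C3)c12` likewise returns only a limit, > 300000 nM. Going by the values given here, compound 3 `COc1ncn(-c2ncc(OC)c3c(C(=O)C(=O)N4CCN(C(=O)c5ccccc5)CC4)c[nH]c23)n1` is the one entry with a number, 285000 nM. Among the compounds with values here, the single measured step, an at least 1.0-fold lower number from compound 2 to compound 3 (0.02 log units; that floor lies within the scatter), stays within the scatter, and the limit of > 300000 nM in this assay, at which 2 of the 3 values shown sit, describes where two of the three values sit.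

Compound 4 `CCCSc1ncn(-c2ncc(OC)c3c(C(=O)C(=O)N4CCN(C(=O)c5ccccc5)CC4)c[nH]c23)n1` differs from compound 2 by propylsulfanyl in place of 4-methylpiperazin-1-yl on an aromatic carbon. Within the data shown here, the only measured step that bears on this is the earlier exchange on an aromatic carbon, from compound 2 to compound 3, which moved the value by an at least 1.0-fold lower number from compound 2 to compound 3 (0.02 log units; that floor lies within the scatter), essentially nothing. On that basis no shift beyond the scatter is expected from compound 2 to compound 4, and the outcome may again be a limit rather than a number.

Compound 4 is therefore estimated at 300000 nM, with a range of 150000 nM to 600000 nM. The expected step is a number no higher from compound 2 to compound 4 (the limit leaves the size open).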

Compound 4, half-maximal cytotoxic concentration: 7000 nM
Compound 4: middle estimate off by 43-fold (1.63 log units), on the high side; measured number outside the range, below it.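

Tolerance in this assay responds strongly to the group on this aromatic carbon of the five-membered aromatic ring with 3 nitrogen: propylsulfanyl in place of 4-methylpiperazin-1-yl gives an at least 42-fold lower number from compound 2 to compound 4 (1.63 log units; beyond the scatter), and propylsulfanyl in place of methoxy gives a 41-fold lower number from compound 3 to compound 4 (1.61 log units; beyond the scatter). The exchange of 4-methylpiperazin-1-yl for methoxy at the same carbon stayed within the scatter, so the position is not indifferent to every change, and among the three groups shown only propylsulfanyl stands apart. The first of these two steps gives a floor rather than a size: the limit of > 300000 nM in this assay, at which 2 of the 4 values shown sit.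

The compounds shown do not separate the sulfur atom from the propyl chain, and a propoxy or a methylsulfanyl group on the same carbon would address that. As far as these compounds go, how the value tracks a longer chain, such as butylsulfanyl, also stays open.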